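The source may hold more compounds than are shown below. What is called first, only, known or untested is meant among the compounds shown, and "the series" means these compounds.

Working notes on the series. Of the compounds shown here, two have numbers so far. Compound 1 `O=C1NC(=O)/C(=C\c2ccc(OCC(=O)N3N=C(c4ccccc4)CC3c3ccc(Cl)c(Cl)c3)cc2)S1` gives 39000 nM in an assay on isolated protein for inhibition of protein deacetylase HDAC6 (Homo sapiens), read by fluorescence, with a stated time of 30 min; on this read-out lower numbers stand for stronger inhibition and higher numbers for weaker inhibition. Compound 2 `O=C1NC(=O)/C(=C\c2ccc(OCC(=O)N3N=C(c4ccc(F)cc4)CC3c3ccco3)cc2)S1` gives 7600 nM in this assay, the lowest of the two numbers, with compound 1 standing at a markedly higher value, beyond the usual scatter. No pair among these two differs in only one place, so the gap cannot be assigned to any single change.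

Compound 3 `O=C1NC(=O)/C(=C\c2ccc(OCC(=O)N3N=C(c4ccc(F)cc4)CC3c3ccc(Cl)c(Cl)c3)cc2)S1` is not yet measured in this assay. It differs from compound 2 in one place: 3,4-dichlorophenyl in place of furan-2-yl on a saturated ring carbon. From the compounds shown here alone, the same 3,4-dichlorophenyl group is also present in compound 1, but compound 1 and compound 3 are not single-step neighbours either, so its weight in the number of compound 1 is unknown.

Within the data shown here, with no measured step for this change, the direction is an open question. Among the measured compounds shown here, a moderate step toward weaker inhibition from compound 2 is expected, a 2.1-fold higher number from compound 2 to compound 3 (0.32 log units; beyond the scatter), because compound 1, the only other number, gives 39000 nM. Compound 3 is estimated at 16000 nM in this assay, within a range from 5000 nM to 50000 nM.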

Compound 3, half-maximal inhibitory concentration: 13000 nM
The estimate for compound 3 lay 1.2-fold (0.09 log units) above the measured number; the measured number falls inside the stated range.
By their numbers in this assay, from the lowest: compounds 2 and 3 (each within the scatter of the next); then compound 1.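

In this assay the saturated ring carbon takes the 8 heavy atoms of 3,4-dichlorophenyl in place of the 5 of furan-2-yl with no difference that can be told apart, a result given by a 1.7-fold higher number from compound 2 to compound 3 (0.23 log units; within the scatter). Among these compounds, the step with 3,4-dichlorophenyl held constant, fluoro in place of hydrogen on an aromatic carbon of the phenyl group, gives a 3.0-fold lower number from compound 1 to compound 3 (0.48 log units; beyond the scatter), so this is the only single change so far that lies beyond the scatter, though its size is modest. No measurement at hand offers a reason for either step.

Among the compounds shown here, whether an amine, a carboxylic acid or a longer chain on the saturated ring carbon would also leave the number unresolved from that of compound 2 remains open, since only two aromatic groups have been compared there. From the compounds shown here alone, it is also open whether the fluoro step carries over when furan-2-yl occupies that carbon, and whether a chloro or methoxy group on the same phenyl ring would give a step of similar size.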